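The source may report more compounds than this note shows. Statements on the series, on what has been measured and on what is new or still open speak of the compounds shown alone.

In a functional assay on DU-145 cells (Homo sapiens) for cytotoxicity, read by MTT assay, with a stated time of 24 h (on this read-out higher numbers stand for weaker inhibition and lower numbers for stronger inhibition), compound 1 `COc1ccc(/C=C2\CN(C(=S)SCc3cn(Cc4ccccc4F)nn3)C/C(=C\c3ccc(OC)cc3)C2=O)cc1` gives 54500 nM and compound 2 `COc1ccc(/C=C2\CN(C(=S)SCc3cn(Cc4ccc(F)cc4)nn3)C/C(=C\c3ccc(OC)cc3)C2=O)cc1` gives 74600 nM. Compound 3 `O=C1/C(=C/c2ccccc2F)CN(C(=S)SCc2cn(Cc3ccccc3F)nn2)C/C1=C\c1ccccc1F` reads > 80000 nM, which is a limit of the assay and not a number. Compound 4 `O=C1/C(=C/c2ccccc2F)CN(C(=S)SCc2cn(Cc3cccc(Cl)c3)nn2)C/C1=C\c1ccccc1F` differs from compound 3 in one place: 3-chlorophenyl in place of 2-fluorophenyl on a saturated chain carbon bound to an aromatic nitrogen. Within the data shown here, the only measured step at this place, made on the core of compound 1, is a 1.4-fold higher number from compound 1 to compound 2 (0.14 log units; within the scatter). No shift beyond the scatter is therefore expected in this assay, and the limit leaves the true size of the step open. The expected change is a number no higher from compound 3 to compound 4 (the limit leaves the size open), nothing beyond the scatter. Compound 4 is estimated at 80000 nM, within a range of 45000 nM to 140000 nM.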

Compound 4, half-maximal inhibitory concentration: > 80000 nM
Compound 4 ended at the assay's limit (the forecaster's own chance of this, stated with the estimate: 55%); the middle value sits exactly at the limit.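

In this assay, among these compounds, compound 3 and compound 4 both rest at a limit of the assay, so no step between them can be read: the limit of > 80000 nM in this assay, at which 2 of the 4 values shown sit.

The compounds shown leave open whether 3-chlorophenyl in place of 2-fluorophenyl changes the read-out at all on this core.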